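Hydroxymethyl in Place of Phenyl on the Imine Chain

This account rests on a few compounds, and the source may have more. Where it says the series, first, only, none or still open, it means among the compounds named here.

Three measured compounds share one core. Compound 1 `O=c1[nH]c2ccccc2cc1/C=N/c1ccccc1O` in a functional assay, read by spectrophotometry, with a stated time of 30 min (on this read-out higher numbers stand for weaker inhibition and lower numbers for stronger inhibition), gives 22800 nM, a weak inhibition. Compound 2 `O=c1[nH]c2ccccc2cc1/C=N/Cc1ccccc1` in this assay is reported only as "not active" (no number reported), with no number, and compound 3 `Cc1ccc2[nH]c(=O)c(/C=N/Cc3ccccc3)cc2c1` in this assay is likewise reported as "not active" (no number reported). Within the data shown here, compound 2 therefore stands among the entries without a single number, and no measured pair differs in one place, so no step size is known. Compound 4 `O=c1[nH]c2ccccc2cc1/C=N/CCO` differs from compound 2 by hydroxymethyl in place of phenyl on a saturated chain carbon bound to a double-bonded nitrogen. With nothing to anchor a step, in this assay the expectation is a change no larger than the scatter, with a fair chance that compound 4 again returns no number. Compound 4 is expected to give about 40000 nM, within 10000 nM to 150000 nM.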

Compound 4, half-maximal inhibitory concentration: "not active" (no number reported)
Nothing numeric was reported for compound 4, so the estimate cannot be set against anything.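

In this assay compound 2 and compound 4 both lack a number, so no step can be read between them. No evidence on a cause is available. On these data alone, whether hydroxymethyl in place of phenyl changes inhibition at all stays open.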